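The compounds below may be only part of what the source reports. "The series", "measured", "known", "first", "only" and "open" are said of these compounds alone.

In a physicochemical assay for lipophilicity, read by HPLC, at pH 7.5 (on this read-out lower numbers stand for lower lipophilicity and higher numbers for higher lipophilicity), compound 3 `CC[C@@H](Nc1c(C#N)c(-c2ccc(-c3ccncc3C)cc2)nc2cnccc12)C(N)=O` gives 2. Among the three measured compounds it stands second highest: compound 1 `CC[C@@H](Nc1c(C#N)c(-c2ccc(-c3cccnc3C)cc2)nc2cnccc12)C(N)=O` gives 1.9, which differs from compound 3 only within the scatter, while compound 2 `CC[C@@H](Nc1c(C#N)c(-c2ccc(-c3ccccc3C(C)C)cc2)nc2cnccc12)C(N)=O` gives 3.5, the highest of the set, so that the step is a number 1.50 log units lower from compound 2 to compound 3 (beyond the scatter).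

Compound 4 `CC[C@@H](Nc1c(C#N)c(-c2ccc(-c3ccc(OC)cc3)cc2)nc2cnccc12)C(N)=O` differs from compound 3 in one place: 4-methoxyphenyl in place of 3-methylpyridin-4-yl on an aromatic carbon. Within the data shown here, two measured steps bear on this exchange of a six-membered aromatic ring with one hetero atom for a ring of carbon only: a number 1.60 log units higher from compound 1 to compound 2 (beyond the scatter) and a number 1.50 log units lower from compound 2 to compound 3 (beyond the scatter). The step of a number 0.10 log units higher from compound 1 to compound 3 (within the scatter) exchanged one such hetero-atom ring for another and stayed within the scatter. Because of a number 1.50 log units lower from compound 2 to compound 3 (beyond the scatter) an upward step beyond the scatter is expected in this assay, though the entering 4-methoxyphenyl is not the 2-isopropylphenyl of compound 2, so a somewhat smaller rise is estimated. Compound 4 is therefore expected to give about 3, between 2.5 and 3.5, an estimated step of a number 1.00 log units higher from compound 3 to compound 4 (beyond the scatter).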

Compound 4, distribution coefficient: 2.7
Beside the measured number, compound 4's estimate is 0.30 log units above it, and the stated range covers the measured number.
By their numbers in this assay, from the lowest: compounds 1 and 3 (each within the scatter of the next); then compound 4; then compound 2.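

At this place, on an aromatic carbon para to a large group, exchanging either methylpyridinyl group for 4-methoxyphenyl gives a number 0.70 log units higher from compound 3 to compound 4 (beyond the scatter) and a number 0.80 log units higher from compound 1 to compound 4 (beyond the scatter) in this assay. A rise beyond the scatter is thus not confined to 2-isopropylphenyl, yet 4-methoxyphenyl does not match that group, with a number 0.80 log units lower from compound 2 to compound 4 (beyond the scatter), so among these compounds the size of the step depends on which ring of carbon only enters. Nothing given here accounts for the size of these steps.

The compounds shown leave open how an unsubstituted phenyl, or a phenyl carrying an amine or a carboxylic acid, would read in this assay. They also do not separate the contribution of the methoxy group from that of its place on the ring.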